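The source may report more compounds than this note shows. Statements on the series, on what has been measured and on what is new or still open speak of the compounds shown alone.

Working notes on the series. In a functional assay on JAR cells (Homo sapiens) for inhibition, read by MTT assay, with a stated time of 72 h (on this read-out lower numbers stand for stronger inhibition and higher numbers for weaker inhibition), compound 2 `CCOC(=O)C1=C(Nc2ccccc2)S/C(=C\c2ccc[nH]2)C1=O` gives 9500 nM, and compound 1 `CCOC(=O)C1=C(Nc2ccccc2)S/C(=C\c2cccc(C(=O)O)c2)C1=O` gives 11700 nM; the two numbers lie within the usual scatter of each other, so neither is set apart. Compound 3 `CCOC(=O)C1=C(Nc2ccccc2)S/C(=C\c2cc3cccnc3[nH]2)C1=O` carries a group of 9 heavy atoms (7 carbon, 2 nitrogen; one five-membered aromatic ring with 1 hetero atom, one six-membered aromatic ring with 1 hetero atom) in place of a group of 5 heavy atoms (4 carbon, 1 nitrogen; one five-membered aromatic ring with 1 hetero atom), on a double-bonded chain carbon bound to a double-bonded ring carbon. Within the data shown here, the only measured step, a 1.2-fold lower number from compound 1 to compound 2 (0.09 log units; within the scatter), swapped one group at the same place and stayed within the scatter; no measured step adds a fused ring at this place. For compound 3 a change of about a 1.2-fold lower number from compound 2 to compound 3 (0.07 log units; within the scatter) in this assay is therefore expected, with no direction supported beyond the scatter. The estimate for compound 3 is 8000 nM, within 2500 nM to 25000 nM.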

Compound 3, half-maximal inhibitory concentration: 14400 nM
Compound 3: the middle estimate sits 1.8-fold (0.26 log units) below what was measured; the range from low to high includes it.
By their numbers in this assay, from the lowest: compounds 2, 1 and 3 (each within the scatter of the next).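

The group of 9 heavy atoms, with one five-membered and one six-membered aromatic ring, gives a 1.5-fold higher number from compound 2 to compound 3 (0.18 log units; within the scatter) and a 1.2-fold higher number from compound 1 to compound 3 (0.09 log units; within the scatter), both in this assay. Among these compounds, a second aromatic ring at this place therefore does not set compound 3 apart from compound 2, a point the earlier compounds could not address, and the three groups tested here remain undistinguished. Nothing available bears on why these groups read alike.

On these data alone, whether a saturated amine or a longer alkyl chain, on a double-bonded chain carbon bound to a double-bonded ring carbon, would move the number beyond the scatter stays open.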